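Changing the Amide Nitrogen Substituent in a Rat Inhibition Series

This account rests on a few compounds, and the source may have more. Where it says the series, first, only, none or still open, it means among the compounds named here.

compound 1 `CC(C)NC(=O)/C=C1\CCc2ccc(F)cc21`: 71%
compound 2 `O=C(/C=C1\CCc2ccc(F)cc21)NC1CCC1`: 0%

Of the compounds shown here, two sharing one core have been measured in a functional assay on the whole organism with Rattus norvegicus as the target, at a dose of 20 mg/kg by the oral route; a lower number here means less inhibition, a higher number more inhibition at the dose given (going by the name of the read-out). Compound 1 `CC(C)NC(=O)/C=C1\CCc2ccc(F)cc21` gives 71% in this assay, and compound 2 `O=C(/C=C1\CCc2ccc(F)cc21)NC1CCC1` gives 0%. Within the data shown here, the single step between them, a number 71 percentage points lower from compound 1 to compound 2 (beyond the scatter), came with cyclobutyl in place of isopropyl on an amide-type nitrogen. Among the measured compounds shown here, compound 2 thus stands lowest of the two numbers; its only neighbour is compound 1, higher by a margin beyond the scatter.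

Compound 3 `CCN(C)C(=O)/C=C1\CCc2ccc(F)cc21` has not yet been measured in this assay. Its change from compound 2 is ethyl(methyl)amino in place of cyclobutylamino on a carbonyl carbon. For the measured compounds named here, the one measured step that bears on this position is a number 71 percentage points lower from compound 1 to compound 2 (beyond the scatter), which was large. It shows how strongly this position can move the read-out, yet it exchanged one ring-free group for a ring, whereas the present change removes the ring and the hydrogen-bond donor, so the direction is not fixed by the data. Compound 3 is expected to show the step of a number 20 percentage points higher from compound 2 to compound 3 (beyond the scatter). Compound 3 is estimated at 20%, with a range from 0% to 55%.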

Compound 3, a percentage reported as inhibition, in the whole organism at one dose (the size of the read-out at that dose, not a potency): 44%
The estimate for compound 3 lay 24 percentage points below the measured number; measured number inside the range.
By their numbers in this assay, from the lowest: compound 2; then compound 3; then compound 1.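

In this assay the position proves able to give back much of the read-out without the amide hydrogen: ethyl(methyl)amino in place of cyclobutylamino on the carbonyl carbon gave a number 44 percentage points higher from compound 2 to compound 3 (beyond the scatter) and so removed both the four-membered ring and the hydrogen-bond donor. The ring-free group without the donor still does not match isopropylamino, with a number 27 percentage points lower from compound 1 to compound 3 (beyond the scatter) as the step, and compound 2 remains the lowest of the three. Nothing measured here accounts for these differences.

On these data alone, the ring and the amide hydrogen left in the same step, so the share of each in the rise from compound 2 remains open. Cyclobutyl(methyl)amino on the same carbonyl carbon would separate the two, while diethylamino would show how a longer chain behaves at this position.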